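A few compounds are considered here, and "the series" means these few. Any claim that something is new, unique, unknown or untested is made for them only; others in the source may bear on it.

Measured compounds:
compound 1 `CCCn1c(-c2ccc(OCc3c(-c4c(Cl)cccc4Cl)noc3C(C)C)cc2)nc2ccc(C(=O)O)cc21`, 1400 nM in an assay on HEK-293T cells for antagonist activity at vitamin D3 receptor (Homo sapiens), read by a luciferase reporter, with a stated time of 24 h; a lower number here means a stronger inhibitor, a higher number a weaker inhibitor
compound 2 `CC(C)c1onc(-c2c(Cl)cccc2Cl)c1COc1ccc(-c2nc3ccc(C(=O)O)cc3n2C2CC2)cc1`, 3200 nM in this assay

Of the two numbers shown, compound 2 carries the higher one; the only other measured compound, compound 1, sits beneath it, and the step between them, a 2.3-fold higher number from compound 1 to compound 2 (0.36 log units; beyond the scatter), lies beyond the scatter. Within the data shown here, that step is the one change at the aromatic nitrogen of the shared core, cyclopropyl in place of propyl.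

Compound 3 `CC(C)c1onc(-c2c(Cl)cccc2Cl)c1COc1ccc(-c2nc3ccc(C(=O)O)cc3n2CC2CCCCC2)cc1` is the unmeasured member. It differs from compound 2 at the same aromatic nitrogen: cyclohexylmethyl in place of cyclopropyl on an aromatic nitrogen. Among the measured compounds shown here, the step from compound 1 to compound 2 is the only measured step that bears on this position, and it shows that the group on this nitrogen moves the number by a modest amount. Compound 1 carries a chain there, compound 2 a small ring. The incoming cyclohexylmethyl is a larger group and pairs a ring with a chain, so neither of the two measured compounds matches it closely. Compound 3 is therefore expected to give a number near that of compound 2, with at most a modest shift, and the step from compound 2 to compound 3 is estimated at a 1.6-fold lower number from compound 2 to compound 3 (0.20 log units; within the scatter). The estimate for compound 3 in this assay is 2000 nM, with a range from 600 nM to 7000 nM.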

Compound 3, half-maximal inhibitory concentration: 346 nM
Compound 3: middle estimate off by 5.8-fold (0.76 log units), on the high side; measured number outside the range, below it.
By their numbers in this assay, from the lowest: compound 3; then compound 1; then compound 2.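

Read together with the earlier step, the new result changes what can be said about the group on this aromatic nitrogen in this assay. The earlier change, a 2.3-fold higher number from compound 1 to compound 2 (0.36 log units; beyond the scatter), had raised the number only modestly, whereas cyclohexylmethyl in place of cyclopropyl brings a 9.2-fold lower number from compound 2 to compound 3 (0.97 log units; beyond the scatter), so this position allows a larger move than that single step showed, and in the opposite direction. A ring as such does not set the direction: compound 2, with its cyclopropyl, has the highest number of the three, while cyclohexyl in place of ethyl on the saturated chain carbon bound to the aromatic nitrogen gives a 4.0-fold lower number from compound 1 to compound 3 (0.61 log units; beyond the scatter), leaving compound 3 the strongest inhibitor of the three; nothing at hand gives a reason for this drop.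

The three compounds leave open whether the lower number goes with the six-membered ring or with the carbon that ties it to the nitrogen, a question that a cyclohexyl set directly on the nitrogen and a hexyl chain could separate. Also open, on these data alone, is whether the same order would hold with an amide in place of the carboxylic acid on the shared core.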